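A bromo group removed from compound 1

A few compounds are considered here, and "the series" means these few. Any claim that something is new, unique, unknown or untested is made for them only; others in the source may bear on it.

Of the compounds shown here, two have so far been measured in an ADME assay on Vero cells (Chlorocebus sabaeus) for cytotoxicity, read by MTT assay, with a stated time of 24 h; on this read-out lower numbers stand for stronger inhibition and higher numbers for weaker inhibition. Compound 1 `O=C(CC1SC(=O)NC1=O)Oc1ccc(/C=N/NC(=O)c2ccncc2)cc1Br` gives 190 ug/mL in this assay. Compound 2 `O=C(/C=C1/SC(=O)NC1=O)Oc1ccccc1/C=N/NC(=O)c1ccncc1` does not give a number in this assay but only a limit of the assay, > 200 ug/mL. Among the results shown, compound 1 therefore stands as the only one with a numerical value, while the other result is a limit, (the limit of > 200 ug/mL in this assay, at which 1 of the 2 values shown sits).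

Compound 3 `O=C(CC1SC(=O)NC1=O)Oc1ccc(/C=N/NC(=O)c2ccncc2)cc1` has not yet been measured in this assay. Set against compound 1 it shows (hydrogen in place of bromo on an aromatic carbon).

Within the data shown here, no step between two measured compounds is available, so the size of the change from compound 1 to compound 3 cannot be read from any neighbouring pair. Both measured results sit at the weak end of the read-out, and nothing shown points to a step beyond the scatter, so the expected step of no change at the digits printed from compound 1 to compound 3 (within the scatter) is one of no change beyond the usual scatter, in either direction. On this basis compound 3 is expected to give about 190 ug/mL in this assay, with a range from 95 ug/mL to 380 ug/mL, and a fair chance that only a limit is reported.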

Compound 3, half-maximal inhibitory concentration: 91.7 ug/mL
Compound 3: middle estimate off by 2.1-fold (0.32 log units), on the high side; the measured number lies below the stated range.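

In this assay, the step at this position is a 2.1-fold lower number from compound 1 to compound 3 (0.32 log units; beyond the scatter), which is modest but lies beyond the scatter. Among these compounds, this gives the first direct reading of this place on the aromatic ring: with bromo replaced by hydrogen and the rest of the structure unchanged, the number falls, which on this read-out stands for stronger inhibition. The change removes just one heavy atom and no ring, donor, acceptor or net charge, yet that is enough to move the result, and nothing shown accounts for the step.

On these data alone, with only bromo and hydrogen compared at this place, it remains open whether the step is tied to bromine itself or would also appear with chloro, fluoro, methyl or methoxy there. As far as these compounds go, it also remains open whether the same replacement would give a step of similar size and direction on a different core, since this single pair cannot show whether the change carries beyond compound 1 and compound 3.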